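The compounds below may be only part of what the source reports. "The series", "measured", "known", "first", "only" and "open" are said of these compounds alone.

Working notes on the series. Within the data shown here, compound 1 `C=CCn1c(=O)n(C2CCC(CO)C2)c2nc(N)nc(O)c21` and compound 2 `CCOC(=O)Cn1c(=O)n(C2OC(CO)[C@@H](O)[C@H]2O)c2nc(N)nc(O)c21` are the two measured members; compound 3 `NC(=O)Cn1c(=O)n(C2OC(CO)[C@@H](O)[C@H]2O)c2nc(N)nc(O)c21` is the unmeasured one. In a functional assay on the whole organism with Mus musculus as the target (on this read-out lower numbers stand for smaller maximal responses and higher numbers for larger maximal responses), compound 1 gives 0%. In this assay compound 2 gives 58%, the higher of the two numbers, and its gap to compound 1 lies beyond the usual scatter. Compound 3 differs from compound 2 in a single place: amino in place of ethoxy on a carbonyl carbon. Among the measured compounds shown here, no step between measured compounds covers this kind of change, so nothing in the present data tells its direction. The working assumption is a small downward drift, close to the edge of the scatter, rather than a loss of the response seen for compound 2; in this assay the expected step is a number 13 percentage points lower from compound 2 to compound 3 (beyond the scatter). For the measured compounds named here, compound 3 is accordingly estimated at 45% in this assay, with a range from 15% to 75% that reflects the single supporting value.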

Compound 3, largest response reached (reported as maximal response), in percent of the reference or control that the assay uses: 72%
Compound 3: middle estimate off by 27 percentage points, on the low side; measured number inside the range.
By their numbers in this assay, from the lowest: compound 1; then compound 2; then compound 3.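

In this assay, among these compounds, amino in place of ethoxy on a carbonyl carbon gives a number 14 percentage points higher from compound 2 to compound 3 (beyond the scatter) and so provides the first reading for this kind of change. At this position the response does not depend on ethoxy, and carbamoylmethyl in place of (ethoxycarbonyl)methyl keeps the response and modestly raises it. Nothing available bears on the reason for this step.

As far as these compounds go, it remains open whether the rise is specific to amino or would also appear with methylamino, dimethylamino or a carboxylic acid on the same carbonyl carbon. Also open, from the compounds shown here alone, is whether a longer chain between the core and the carbonyl carbon would keep the response, and whether the same exchange would act alike on the core of compound 1.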